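Hydroxyl position on the aryl at the alkene carbon

The compounds below may be only part of what the source reports. "The series", "measured", "known", "first", "only" and "open" are said of these compounds alone.

Compound 1 `CC1=C(c2cccc(O)c2)C(c2ccc(OC[C@H](C)N3CC[C@@H](C)C3)cc2)Oc2ccc(O)cc21` is one of three stereoisomers that share one core. In a functional assay on MCF7 cells (Homo sapiens) for antiproliferative activity, read by CellTiter-Glo, with a stated time of 5 days (a higher number here means a weaker inhibitor, a lower number a stronger inhibitor), compound 1 gives 0.2 nM. Compound 2 `CC1=C(c2cccc(O)c2)C(c2ccc(OC[C@@H](C)N3CC[C@H](C)C3)cc2)Oc2ccc(O)cc21` gives 0.2 nM and compound 3 `CC1=C(c2cccc(O)c2)C(c2ccc(OC[C@H](C)N3CC[C@H](C)C3)cc2)Oc2ccc(O)cc21` gives 0.2 nM in this assay. The steps among them are flat: no change at the digits printed from compound 1 to compound 2 (within the scatter), no change at the digits printed from compound 1 to compound 3 (within the scatter) and no change at the digits printed from compound 2 to compound 3 (within the scatter). Compound 1 therefore stands level with compound 2 and compound 3 at the digits shown, with no order among the three.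

Compound 4 `CC1=C(c2ccc(O)cc2)C(c2ccc(OC[C@H](C)N3CC[C@@H](C)C3)cc2)Oc2ccc(O)cc21` is not yet measured. It differs from compound 1 by 4-hydroxyphenyl in place of 3-hydroxyphenyl on a double-bonded ring carbon. Within the data shown here, none of the measured steps touches this position: all three concern only the drawn configuration at the saturated chain carbon and the saturated ring carbon, and all lie within the scatter. Among the measured compounds shown here, no measured step therefore gives a size for the change to compound 4 in this assay, and the expectation rests on compound 1 alone.

For compound 4 a small loss is estimated, a 2.5-fold higher number from compound 1 to compound 4 (0.40 log units; beyond the scatter), placing it at an expected 0.5 nM with a range from 0.1 nM to 3 nM.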

Compound 4, half-maximal inhibitory concentration: 0.1 nM
Beside the measured number, compound 4's estimate is 5.0-fold (0.70 log units) above it; the range from low to high includes it.
By their numbers in this assay, from the lowest: compounds 4, 1, 2 and 3 (each within the scatter of the next).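

With this assay as the read-out, the exchange of 3-hydroxyphenyl for 4-hydroxyphenyl on the double-bonded ring carbon gives a 2.0-fold lower number from compound 1 to compound 4 (0.30 log units; within the scatter) and so does not separate the two groups. Among these compounds, this is the first reading at this position, since the earlier steps touched only the drawn configuration of the side chain, and it shows that compound 1 and compound 4 cannot be told apart when only the place of the hydroxyl on this aryl changes. Nothing at hand speaks to why the two compounds read alike.

Still open, as far as these compounds go, is whether this aryl needs a hydroxyl at all, as an unsubstituted phenyl or a methoxyphenyl would show, and how 2-hydroxyphenyl reads here. Also open, from the compounds shown here alone, is whether the other stereoisomers of compound 4 read level with it, as compounds 1, 2 and 3 do with each other.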